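Replacing an amidoxime-bearing ring by pyridin-4-yl on the shared core

The source may report more compounds than this note shows. Statements on the series, on what has been measured and on what is new or still open speak of the compounds shown alone.

Measured compounds:
compound 1 `CC1(c2ccc(-c3ccc(/C(N)=N\O)cc3)cc2)CC(S(=O)(=O)c2ccc(F)cc2)=C(c2ccc(/C(N)=N\O)cc2)O1` — 3940 nM
compound 2 `CC1(c2ccccc2)CC(S(=O)(=O)c2ccc(F)cc2)=C(c2ccc(/C(N)=N\O)cc2)O1` — 29700 nM
compound 3 `CC1(c2ccc(-c3cccc(/C(N)=N\O)c3)cc2)CC(S(=O)(=O)c2ccc(F)cc2)=C(c2ccc(/C(N)=N\O)cc2)O1` — 11000 nM

These three share one core and were tested in an ADME assay on J774.A1 cells (Mus musculus) for cytotoxicity, read by MTT assay, with a stated time of 72 h; on this read-out lower numbers stand for higher toxicity in this test and higher numbers for lower toxicity in this test. Compound 3 stands second highest of the three numbers: its nearest neighbour is compound 2, with a 2.7-fold lower number from compound 2 to compound 3 (0.43 log units; beyond the scatter), and its furthest is compound 1, with a 2.8-fold higher number from compound 1 to compound 3 (0.45 log units; beyond the scatter). Compound 4 `CC1(c2ccc(-c3ccncc3)cc2)CC(S(=O)(=O)c2ccc(F)cc2)=C(c2ccc(/C(N)=N\O)cc2)O1` differs from compound 3 in one place: a group of 6 heavy atoms (5 carbon, 1 nitrogen; one six-membered aromatic ring with 1 hetero atom) in place of a group of 10 heavy atoms (7 carbon, 2 nitrogen, 1 oxygen; one six-membered aromatic ring of carbon only), on an aromatic carbon. The ring that leaves carries the amidoxime; the pyridin-4-yl that enters carries none.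

Going by the values given here, two measured steps bear on this. Adding the amidoxime-bearing ring to the bare phenyl of compound 2 gave a 2.7-fold lower number from compound 2 to compound 3 (0.43 log units; beyond the scatter), and moving the amidoxime within that ring gave a 2.8-fold higher number from compound 1 to compound 3 (0.45 log units; beyond the scatter). Compound 4 keeps a second ring but drops the amidoxime altogether, which places it somewhere between compound 3 and the unsubstituted compound 2. A modest upward step in this assay is therefore expected, a 1.4-fold higher number from compound 3 to compound 4 (0.13 log units; within the scatter), though a value close to that of compound 3 cannot be excluded. For compound 4 the estimate is 15000 nM, with a range from 6000 nM to 35000 nM.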

Compound 4, half-maximal cytotoxic concentration: 6750 nM
Beside the measured number, compound 4's estimate is 2.2-fold (0.35 log units) above it, and the stated range covers the measured number.
By their numbers in this assay, from the lowest: compounds 1, 4 and 3 (each within the scatter of the next, the first and the last beyond it); then compound 2.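

In this assay, exchanging the amidoxime-bearing ring for pyridin-4-yl gives a 1.6-fold lower number from compound 3 to compound 4 (0.21 log units; within the scatter) and, against the other amidoxime-bearing isomer, a 1.7-fold higher number from compound 1 to compound 4 (0.23 log units; within the scatter) so compound 4 cannot be told apart from either, even though compound 1 and compound 3 differ from each other beyond the scatter. Set against the bare phenyl, pyridin-4-yl in place of hydrogen gives a 4.4-fold lower number from compound 2 to compound 4 (0.64 log units; beyond the scatter) and this is the new information: in the earlier compounds every added ring carried an amidoxime, whereas here a second ring without one still goes with a lower number than compound 2. At this position, then, the amidoxime on the added ring is not required for the lower number seen with compound 1 and compound 3, although nothing shown here gives a reason for these numbers.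

The compounds shown leave open whether the ring nitrogen of pyridin-4-yl plays any part, which a plain phenyl at the same place would test. They also leave open whether a ring is needed at all, or whether a smaller group such as methyl or a chlorine atom would go with a similar number.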